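The source may hold more compounds than are shown below. What is called first, only, known or untested is meant among the compounds shown, and "the series" means these compounds.

Measured so far in a functional assay on SK-OV-3 cells (Homo sapiens) for antiproliferative activity, read by MTT assay, with a stated time of 24 h; a lower number here means a stronger inhibitor, a higher number a weaker inhibitor:
compound 1 `COc1cccc(/C=C/C(=O)c2ccc(OC)c3c2OC(C)(C)C=C3)c1` gives 9360 nM.
compound 2 `COc1cc(OC)c(OC)cc1/C=C/C(=O)c1ccc(OC)c2c1OC(C)(C)C=C2` gives > 10000 nM, a limit of the assay rather than a number.
compound 3 `COc1ccc(C(=O)/C=C/c2ccc3ccccc3n2)c2c1C=CC(C)(C)O2` gives 2350 nM.

Among the two numbers in this assay, compound 1 stands at the higher one; compound 3 sits at a lower value, and that gap is beyond the scatter. Compound 2 returns only (the limit of > 10000 nM in this assay, at which 1 of the 3 values shown sits), so it gives no number to compare. Within the data shown here, no pair of measured compounds differs in a single place, so no measured step is available to set a scale.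

Compound 4 `COc1ccc(/C=C/C(=O)c2ccc(OC)c3c2OC(C)(C)C=C3)cn1` is derived from compound 1 by a single change, (6-methoxypyridin-3-yl in place of 3-methoxyphenyl on a double-bonded chain carbon bound to a double-bonded chain carbon). With no measured step of this kind in hand, the expectation rests on the values of compound 1 and compound 3 alone. A step from compound 1 that stays within the scatter, leaning if anything toward a somewhat lower number, is expected; an expected step of a 1.2-fold lower number from compound 1 to compound 4 (0.10 log units; within the scatter) is taken as the working figure. Compound 4 is therefore estimated at 7500 nM in this assay, with a range from 3000 nM to 18000 nM. Since compound 1 already sits close to the limit of the assay, a limit report for compound 4 cannot be ruled out.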

Compound 4, half-maximal inhibitory concentration: > 10000 nM
Compound 4: no number, only a limit (the forecaster's own chance of this, stated with the estimate: 30%); middle value at least 1.3-fold (0.12 log units) away from the limit.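

In this assay compound 4 gives > 10000 nM, which is a limit of the assay and not a number. Among these compounds, this yields the first single-place step, an at least 1.0-fold higher number from compound 1 to compound 4 (0.02 log units; that floor lies within the scatter), and since that figure is only a floor, it shows that placing 6-methoxypyridin-3-yl in place of 3-methoxyphenyl on a double-bonded chain carbon bound to a double-bonded chain carbon brings no measurable move toward a lower number, while the true size of any rise cannot be read. A ring nitrogen in the entering group is therefore not enough on its own to reach a value like that of compound 3, 2350 nM. The series now leans heavily on the ceiling of the assay: the limit of > 10000 nM in this assay, at which 2 of the 4 values shown sit.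

Going by these compounds, how far the value of compound 4 lies past that limit remains open, and with it whether the change is neutral or harmful at this place. Also open, on these data alone, is whether an amine or a carboxylic acid in place of the methoxy group on the entering ring would give a readable number on the shared core.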